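The source may hold more compounds than are shown below. What is called first, only, known or untested is meant among the compounds shown, and "the series" means these compounds.

Measured compounds:
compound 1 `CCOc1cc(-c2cccnc2)ccc1C(N)=O` — 2200 nM
compound 2 `NC(=O)c1ccc(-c2cccnc2)cc1` — 8800 nM
compound 3 `CC(C)Oc1cc(-c2cccnc2)ccc1C(N)=O` — 880 nM

In an assay on cells for inhibition of MAP kinase-interacting serine/threonine-protein kinase 1 (Homo sapiens), read by mobility shift assay, with stated times of 10 min and 60 min, in the presence of a further agent that is not named here (on this read-out lower numbers stand for stronger inhibition and higher numbers for weaker inhibition), compound 3 gives the lowest number of the three, with the nearest being compound 1 and the furthest compound 2. Compound 4 `NC(=O)c1ccc(-c2cccnc2)cc1O` differs from compound 3 by hydrogen in place of isopropyl on an oxygen on an aromatic ring, so the isopropoxy becomes hydroxy. Among the compounds with values here, no hydroxy analogue has been measured. The bearing steps are a 10-fold lower number from compound 2 to compound 3 (1.00 log units; beyond the scatter), a 2.5-fold lower number from compound 1 to compound 3 (0.40 log units; beyond the scatter) and a 4.0-fold higher number from compound 1 to compound 2 (0.60 log units; beyond the scatter): loss or shortening of the alkoxy group raised the number each time. Removing the isopropyl while keeping the oxygen is expected to fall between these cases, so a higher number is expected, a 4.5-fold higher number from compound 3 to compound 4 (0.66 log units; beyond the scatter). Compound 4 is estimated at 4000 nM, range 1500 nM to 12000 nM.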

Compound 4, half-maximal inhibitory concentration: 4300 nM
Compound 4: middle estimate off by 1.1-fold (0.03 log units), on the low side; the range from low to high includes it.
By their numbers in this assay, from the lowest: compound 3; then compounds 1 and 4 (each within the scatter of the next); then compound 2.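

In this assay, hydroxy in place of hydrogen on the aromatic carbon gives a 2.0-fold lower number from compound 2 to compound 4 (0.31 log units; beyond the scatter) and so already counts with the oxygen alone, with no alkyl group on it. Hydrogen in place of ethyl on that oxygen gives a 2.0-fold higher number from compound 1 to compound 4 (0.29 log units; within the scatter) and is not separated from the ethoxy of compound 1. Hydrogen in place of isopropyl gives a 4.9-fold higher number from compound 3 to compound 4 (0.69 log units; beyond the scatter), so at this oxygen only the isopropyl shows a clear gain over hydrogen.

As far as these compounds go, whether a longer chain such as butoxy, or an amine, at this place would go beyond the isopropoxy of compound 3 stays open. Nothing available explains these steps.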